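Ester variation on a thiophene-bearing dihydropyrimidinone series

The source may report more compounds than this note shows. Statements on the series, on what has been measured and on what is new or still open speak of the compounds shown alone.

Measured compounds in an assay on membranes from HeLa cells for displacement of a labelled ligand from adenosine receptor A3 (Homo sapiens), read by scintillation counting, with a stated time of 180 min, tested at 1 uM; on this read-out higher numbers stand for more inhibition at the one concentration tested (going by the name of the read-out) and lower numbers for less inhibition:
compound 1 `CCNC(=O)C1=C(C)NC(=O)NC1c1ccsc1`, 1%
compound 2 `CCC(CC)OC(=O)C1=C(C)NC(=O)NC1c1ccsc1`, 6%

Compound 2 gives the higher of the two numbers, but the step of a number 5 percentage points higher from compound 1 to compound 2 (within the scatter) is within the scatter, so the two compounds are indistinguishable on this read-out. Compound 3 `CC1=C(C(=O)OC2CCC2)C(c2ccsc2)NC(=O)N1` differs from compound 2 by cyclobutyl in place of pentan-3-yl on an oxygen next to a carbonyl group. Among the measured compounds shown here, the only measured step, a number 5 percentage points higher from compound 1 to compound 2 (within the scatter), concerns the same carbonyl substituent and is small. For the measured compounds named here, no step in this assay beyond the scatter has been seen, so the change from compound 2 to compound 3 is expected to produce a number 1 percentage points lower from compound 2 to compound 3 (within the scatter), that is, nothing beyond the scatter. Compound 3 is estimated to give 5%, in the range -5% to 15%.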

Compound 3, a percentage reported as inhibition, at one concentration (the size of the read-out at that concentration, not a potency): 3%
Beside the measured number, compound 3's estimate is 2 percentage points above it; the range from low to high includes it.
By their numbers in this assay, from the lowest: compounds 1, 3 and 2 (each within the scatter of the next).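

In this assay, cyclobutyl on an oxygen next to a carbonyl group cannot be told apart from pentan-3-yl (a number 3 percentage points lower from compound 2 to compound 3 (within the scatter)), so a four-membered ring and an open chain read alike at this position. Cyclobutyloxy in place of ethylamino on the carbonyl carbon also stays within the scatter (a number 2 percentage points higher from compound 1 to compound 3 (within the scatter)). No evidence bears on why these numbers coincide.

Still open, on these data alone, is whether any group on this carbonyl carbon moves the number beyond the scatter, such as a carboxylic acid, a longer chain on the oxygen, or a benzyl group.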